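The source may hold more compounds than are shown below. What is called first, only, known or untested is meant among the compounds shown, and "the series" means these compounds.

Compound 1 `O=C(NO)c1cccc(OCc2ccc(-c3noc(-c4ccc(Br)cc4)n3)cc2)c1`: > 100000 nM
Compound 2 `CCc1nc(-c2ccc(COc3cc(C(=O)NO)ccc3OC)cc2)no1`: 8220 nM

For the measured compounds named here, in an assay on isolated protein for inhibition of sphingomyelin phosphodiesterase (Homo sapiens), read by fluorescence, with a stated time of 30 min (on this read-out lower numbers stand for stronger inhibition and higher numbers for weaker inhibition), compound 2 gives 8220 nM, the only plain number among the two values shown. Compound 1 is reported only as a limit of this assay, > 100000 nM. That limit is the limit of > 100000 nM in this assay, at which 1 of the 2 values shown sits. Compound 3 `COc1ccc(C(=O)NO)cc1OCc1ccc(-c2noc(-c3ccc(Br)cc3)n2)cc1` keeps the core of compound 2 and carries 4-bromophenyl in place of ethyl on an aromatic carbon, that is 4-bromophenyl in place of ethyl on an aromatic carbon. Going by the values given here, no measured pair differing in a single place is available, so the size of this step is open. Among the compounds with values here, compound 1 also carries a 4-bromophenyl and gives only a limit, but it differs from compound 2 in more than one place and so sets no step. For compound 3 the expected step is a 3.0-fold higher number from compound 2 to compound 3 (0.48 log units; beyond the scatter) in this assay, a weakening that may reach beyond the usual scatter. The estimate for compound 3 in this assay is 25000 nM, within a range from 4000 nM to 100000 nM.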

Compound 3, half-maximal inhibitory concentration: > 100000 nM
Compound 3 ended at the assay's limit; the forecaster's own chance of this, stated with the estimate: 30%; middle value at least 4.0-fold (0.60 log units) from the limit.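

On the aromatic carbon of the five-membered aromatic ring, next to the ring nitrogen and the ring oxygen, 4-bromophenyl in place of ethyl now has a readable effect in this assay: an at least 12-fold higher number from compound 2 to compound 3 (1.08 log units; beyond the scatter). From the compounds shown here alone, compound 3 is reported only as a limit, so this size is a lower bound and the full size of the weakening is unknown. Compound 1 and compound 3 both carry 4-bromophenyl at this position, and both stand at the same limit: the limit of > 100000 nM in this assay, at which 2 of the 3 values shown sit.

Going by these compounds, the step for methoxy in place of hydrogen between compound 1 and compound 3 cannot be read, so what methoxy contributes alongside 4-bromophenyl stays unknown. On these data alone, it also remains open whether methyl, a longer chain such as propyl, an unsubstituted phenyl or an amine on this carbon would give a number nearer that of compound 2.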